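The compounds below may be only part of what the source reports. "The series", "measured", "known", "first", "only" and "open" are said of these compounds alone.

Measured compounds:
compound 1 `O=[N+]([O-])c1cccc(NS(=O)(=O)c2ccccc2)c1` — 7.93
compound 2 `COc1ccc(S(=O)(=O)Nc2cccc([N+](=O)[O-])c2)cc1` — 8.44
compound 3 `O=S(=O)(Nc1ccc(F)cc1)c1ccccc1` — 8.85

The study looks at three measured sulfonamides and a fourth, compound 4 `COc1ccc(S(=O)(=O)Nc2ccc(F)cc2)cc1`, that has not yet been measured. In a physicochemical assay for acid dissociation, compound 1 gives 7.93, compound 2 gives 8.44 and compound 3 gives 8.85, the highest of the three. The difference between the core of compound 1 and the core of compound 3 is not broken down here.

Compound 1 and compound 2 differ by one change, (methoxy in place of hydrogen on an aromatic carbon), and this change produced a number 0.51 log units higher from compound 1 to compound 2 (beyond the scatter). Compound 4 differs from compound 3 by the same change, (methoxy in place of hydrogen on an aromatic carbon), made at the same place: on an aromatic carbon of a six-membered aromatic ring of carbon only, para to a large group. It occurs twice among these compounds, once measured and once not.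

Among the measured compounds shown here, because the single measured instance of this change gave a number 0.51 log units higher from compound 1 to compound 2 (beyond the scatter), a step of similar size is expected on the core of compound 3. The step from compound 3 to compound 4 is therefore estimated at a number 0.50 log units higher from compound 3 to compound 4 (beyond the scatter) in this assay. Compound 4 is expected to give about 9.35, most likely between 9 and 9.7.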

Compound 4, acid dissociation constant: 9.32
Compound 4: middle estimate off by 0.03 log units, on the high side; low and high end bracket the measured number.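

In this assay, methoxy in place of hydrogen on an aromatic carbon gave a number 0.47 log units higher from compound 3 to compound 4 (beyond the scatter), which points the same way as a number 0.51 log units higher from compound 1 to compound 2 (beyond the scatter) and is close to it in size, so in these two pairs the change carried from the core of compound 1 to the core of compound 3. Among the compounds shown here, this is agreement across only two cores and at one place, on an aromatic carbon of a six-membered aromatic ring of carbon only, para to a large group, and it sets no rule for any other core. Nothing available here accounts for the size of either step.

The compounds shown leave open whether an amine, a carboxylic acid or a longer chain such as ethoxy at that same place would move the number in this assay in a similar way. They also leave open whether methoxy would give a similar step on a core carrying a nitrile or a trifluoromethyl group.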